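The source may hold more compounds than are shown below. What is called first, only, known or untested is meant among the compounds shown, and "the series" means these compounds.

Measured so far in a functional assay on HCT-116 cells (Homo sapiens) for antiproliferative activity, read by sulforhodamine B assay, with a stated time of 72 h (a higher number here means a weaker inhibitor, a lower number a stronger inhibitor), for the series
compound 1 `Cn1cc(-c2ccc(=O)n(CCOc3ccnc4cc(OCCCCCCC(=O)NO)ccc34)n2)cn1` gives > 10000 nM as a limit
compound 2 `Cn1cc(-c2ccc(=O)n(CCOc3ccnc4cc(OCc5ccc(C(=O)Nc6ccccc6N)cc5)ccc34)n2)cn1` gives 1800 nM as a number
compound 3 `Cn1cc(-c2ccc(=O)n(CCOc3ccnc4cc(OCc5ccc(/C=C/C(=O)Nc6ccccc6N)cc5)ccc34)n2)cn1` gives > 10000 nM as a limit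

Compound 3 has only a limit to show (the limit of > 10000 nM in this assay, at which 2 of the 3 values shown sit). Compound 4 `Cn1cc(-c2ccc(=O)n(CCOc3ccnc4cc(OCc5ccc(CCC(=O)Nc6ccccc6N)cc5)ccc34)n2)cn1` has 2-((2-aminophenyl)carbamoyl)ethyl in place of 2-((2-aminophenyl)carbamoyl)ethenyl on an aromatic carbon of a six-membered aromatic ring of carbon only, para to a large group (2-((2-aminophenyl)carbamoyl)ethyl in place of 2-((2-aminophenyl)carbamoyl)ethenyl on an aromatic carbon).

Among the measured compounds shown here, one measured step bears on this change (an at least 5.5-fold higher number from compound 2 to compound 3 (0.74 log units; beyond the scatter)), where 2-((2-aminophenyl)carbamoyl)ethenyl took the place of (2-aminophenyl)carbamoyl on an aromatic carbon. For the measured compounds named here, no measured step covers the exchange of the ethenyl group for the ethyl group itself. Going by the values given here, compound 2 at 1800 nM is the only number, so the expectation rests on a thin base. In this assay the expected result is a modest move to a lower number (an at least 2.0-fold lower number from compound 3 to compound 4 (0.30 log units; that floor lies within the scatter)), although a reading that stays at the limit is also expected to be quite possible. The estimate for compound 4 is 5000 nM with an expected range from 1500 nM to 16000 nM for this measurement.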

Compound 4, half-maximal inhibitory concentration: > 10000 nM
Compound 4 ended at the assay's limit; the forecaster's own chance of this, stated with the estimate: 45%; middle value at least 2.0-fold (0.30 log units) away from the limit.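

In this assay, compound 4 gives > 10000 nM, which is a limit of the assay, so replacing the ethenyl group with the ethyl group does not restore a measurable value. Compared with the (2-aminophenyl)carbamoyl group attached directly to the aromatic carbon, the ethyl-linked group gives an at least 5.5-fold higher number from compound 2 to compound 4 (0.74 log units; beyond the scatter); the loss seen with the ethenyl-linked group therefore does not depend on the double bond that compound 4 lacks, and compound 2 remains the only compound in the series with a number. The exchange of ethenyl for ethyl itself cannot be read because compound 3 and compound 4 both sit at the limit: the limit of > 10000 nM in this assay, at which 3 of the 4 values shown sit.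

From the compounds shown here alone, whether compound 3 and compound 4 differ in strength remains open, since neither has a value beyond its limit. Going by these compounds, it is also open whether a single methylene link in place of the ethyl chain would keep a reading close to that of compound 2, or whether a fluorine on the aminophenyl ring would change the reading of the directly attached amide.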